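A few compounds are considered here, and "the series" means these few. Any claim that something is new, unique, unknown or untested is made for them only; others in the source may bear on it.

Measured so far:
- compound 1 `CC#C[C@]1(c2ccc(Oc3ccc(C(F)(F)F)cc3Cl)cc2)C[C@H]1C(=O)O` gives > 40000 nM in a functional assay on CHO cells for agonist activity at Free fatty acid receptor 1 (Mus musculus), read by FLIPR and calcium flux; a higher number here means that more compound is needed for the effect, a lower number that less compound is needed
- compound 2 `CC#CC(c1ccc(OCc2ccccc2)cc1)C1OC(=O)NC1=O` gives 3710 nM in this assay
- compound 3 `CC#CC(CC(=O)O)c1ccc(Oc2ncc(C(F)(F)F)cc2Cl)cc1` gives 95 nM in this assay

The value for compound 1 is a limit of this assay, not a number (the limit of > 40000 nM in this assay, at which 1 of the 3 values shown sits). Compound 1 therefore stands at the top of the range shown, with no measured step connecting it to compound 2 or compound 3.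

Compound 4 `CC#C[C@]1(c2ccc(Oc3ccc(C(F)(F)F)cc3Cl)cc2)C[C@@H]1C(=O)O` is not yet measured. It differs from compound 1 in this way: the two compounds have the same atoms and bonds and differ only in configuration as drawn: 1 of 2 stereo elements differ; a stereocentre at a saturated ring carbon is drawn R in compound 1 and S in compound 4. Among the measured compounds shown here, no measured pair shows a change of configuration alone, so the size of the step is open. Compound 3, which carries the same acid and aryl ether without the ring, gives 95 nM, so a stronger value for compound 4 than for compound 1 is at least plausible. The estimate for compound 4 in this assay is 2000 nM, expected to lie between 150 nM and 40000 nM, which means an expected step of an at least 20-fold lower number from compound 1 to compound 4 (1.30 log units; beyond the scatter).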

Compound 4, half-maximal effective concentration: 871 nM
Compound 4: middle estimate off by 2.3-fold (0.36 log units), on the high side, and the stated range covers the measured number.
By their numbers in this assay, from the lowest: compound 3; then compound 4; then compound 2. At a limit, above all of these: compound 1.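

Configuration at this saturated ring carbon matters in this assay, with an at least 45-fold lower number from compound 1 to compound 4 (1.66 log units; beyond the scatter), the only step shown that changes configuration alone. The step can be assigned to that one stereocentre because nothing else changes: the fact that compounds 1 and 4 differ only in the configuration as drawn Its true size remains unknown because compound 1 stands at a limit of the assay: the limit of > 40000 nM in this assay, at which 1 of the 4 values shown sits.

Going by these compounds, the effect of the other stereo element remains open. Also open, on these data alone, is whether a primary amide in place of the carboxylic acid would keep the same preference for the carbon drawn S.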